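Methoxy in place of vinyl on the aromatic carbon

The source may hold more compounds than are shown below. What is called first, only, known or untested is meant among the compounds shown, and "the series" means these compounds.

In an assay on isolated protein for inhibition of malate dehydrogenase, mitochondrial (Sus scrofa), with stated times of 45 min and 30 min (a lower number here means a stronger inhibitor, a higher number a weaker inhibitor), compound 1 `Cc1ccc(S(=O)(=O)Nc2ccc(-c3nc4ccccc4o3)cc2)cc1` gives only a limit, > 63000 nM. Compound 2 `C=Cc1ccc(S(=O)(=O)Nc2ccc(-c3nc4ccccc4o3)cc2)cc1` likewise gives only a limit, > 63000 nM. The step that the two limits leave unreadable from compound 1 to compound 2 cannot be sized, since both values sit at the same limit (the limit of > 63000 nM in this assay, at which 2 of the 2 values shown sit). Compound 3 `COc1ccc(S(=O)(=O)Nc2ccc(-c3nc4ccccc4o3)cc2)cc1` is not yet measured; it differs from compound 2 by methoxy in place of vinyl on an aromatic carbon. Among the measured compounds shown here, only the step from compound 1 to compound 2 concerns this part of the structure, and that step is unreadable, so no measured step gives a direction for the change to compound 3. Nothing in the shown values of the series has moved off the limit, and there is no basis for expecting a step in this assay beyond the scatter. For compound 3 the estimate is 100000 nM, with a range of 40000 nM to 300000 nM, most probably again reported as a limit, and the expected step is a step that the limit leaves unreadable from compound 2 to compound 3.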

Compound 3, half-maximal inhibitory concentration: > 63000 nM
Compound 3: a limit, no number; the forecaster's own chance of this, stated with the estimate: 85%; the middle value lies beyond the limit too.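

Among the compounds shown here, no step among compound 1, compound 2 and compound 3 can be read in this assay, as each value is only a limit: the limit of > 63000 nM in this assay, at which 3 of the 3 values shown sit. The compounds shown leave open whether any group at this place, or any change to the shared core, gives a measurable value.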